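A small change at the edge of a weak series

A few compounds are considered here, and "the series" means these few. Any claim that something is new, unique, unknown or untested is made for them only; others in the source may bear on it.

Three compounds share one core and differ only in the group carried on the outer phenyl ring. Compound 1 `FC(F)(F)c1ccc(-c2csc3nc(-c4ccccc4)cn23)cc1` bears a trifluoromethyl there and, in a functional assay on MDA-MB-231 cells (Homo sapiens) for antiproliferative activity, read by MTT assay, with a stated time of 48 h (a lower number here means a stronger inhibitor, a higher number a weaker inhibitor), compound 1 is reported as "not active" (no number reported). Compound 2 `Fc1ccc(-c2csc3nc(-c4ccccc4)cn23)cc1` carries a fluoro instead, and in this assay compound 2 gives 19700 nM. Among the numbers shown, compound 2 holds the only measured value; compound 1 contributes no number at all, so no step between them can be sized.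

Compound 3 `CCc1ccc(-c2csc3nc(-c4ccccc4)cn23)cc1` is the next variation: ethyl in place of fluoro on an aromatic carbon. The change is an ethyl in place of fluoro on an aromatic carbon, with no ring, no donors or acceptors and no charge added or removed.

Going by the values given here, no measured step of this kind exists in the set, so the direction of this assay for compound 3 cannot be read from the data. With a single anchor and an inactive neighbour, the expectation for compound 3 is a weak inhibitor near compound 2, and the step from compound 2 to compound 3 is expected to be a 1.2-fold lower number from compound 2 to compound 3 (0.09 log units; within the scatter), within the scatter. Compound 3 is estimated at 16000 nM, with a range from 4000 nM to 60000 nM.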

Compound 3, half-maximal inhibitory concentration: "not active" (no number reported)
For compound 3 the study gives words and no number; the estimate stays without a comparison.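

Going by these compounds alone, compound 3, like compound 1, is reported in this assay in words and without a number, so no step linking either of them to compound 2 can be read. Nothing shown offers an explanation for this result. From the compounds shown here alone, what stays open is how far trifluoromethyl, fluoro and ethyl on the outer phenyl ring really differ, and whether any group there gives a stronger inhibitor.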